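Removing the Chlorine from Compound 3

A few compounds are considered here, and "the series" means these few. Any claim that something is new, unique, unknown or untested is made for them only; others in the source may bear on it.

Compound 3 `O=C1CCc2cc(OCc3cccc(Cl)c3)ccc2N1` gives 620 nM in an assay on isolated protein for inhibition of Amine oxidase [flavin-containing] B (Homo sapiens), read by fluorescence and spectrophotometry, with a stated time of 20 min (a lower number here means a stronger inhibitor, a higher number a weaker inhibitor), the highest number among the three compounds measured. Compound 1 `O=C1CCc2ccc(OCc3cccc(Cl)c3)cc2N1` gives 6.2 nM and compound 2 `O=C1CCc2ccc(OCc3cccc(Br)c3)cc2N1` gives 2.9 nM in this assay. Compound 4 `O=C1CCc2cc(OCc3ccccc3)ccc2N1` differs from compound 3 by hydrogen in place of chloro on an aromatic carbon. Within the data shown here, the only measured step on that pendant ring is a 2.1-fold lower number from compound 1 to compound 2 (0.33 log units; beyond the scatter), a modest change for swapping one halogen for another; no measured pair shows a halogen removed altogether. A step in the opposite direction, toward a higher number once the halogen is gone, is expected, so a 2.1-fold higher number from compound 3 to compound 4 (0.32 log units; beyond the scatter) is estimated. Compound 4 is therefore expected to give about 1300 nM, within a range of 400 nM to 4000 nM.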

Compound 4, half-maximal inhibitory concentration: 4010 nM
Compound 4: middle estimate off by 3.1-fold (0.49 log units), on the low side, and the stated range ends below it.
By their numbers in this assay, from the lowest: compound 2; then compound 1; then compound 3; then compound 4.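

Hydrogen in place of chloro gives a 6.5-fold higher number from compound 3 to compound 4 (0.81 log units; beyond the scatter) in this assay, so on this core the chloro on the pendant ring counts for a clear share of the inhibition. The earlier compounds shown here only exchanged one halogen for another, and none showed this ring without a halogen. No measurement here accounts for the rise.

On these data alone, whether the same removal would cost as much on the core of compound 1 stays open. So does how a methoxy or a nitrile would compare with chloro on this aromatic carbon.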